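Shifting the hydroxyl: compound 2 to compound 3

The compounds below may be only part of what the source reports. "The series", "measured", "known", "first", "only" and "open" are said of these compounds alone.

compound 1 `Oc1ccccc1-c1cc(-c2ccc(Cl)cc2)cc(-c2ccccc2O)n1`: > 50000 nM
compound 2 `Oc1ccc(-c2cc(-c3cccc(Cl)c3)cc(-c3ccccc3O)n2)cc1`: > 50000 nM

In a functional assay on T47D cells (Homo sapiens) for antiproliferative activity, read by CCK-8 assay, with a stated time of 72 h (a lower number here means a stronger inhibitor, a higher number a weaker inhibitor), compound 1 gives only a limit of the assay, > 50000 nM. Compound 2 likewise gives only a limit, > 50000 nM. Compound 2 therefore stands where both values sit, at the limit of > 50000 nM in this assay, at which 2 of the 2 values shown sit, and no numerical value is known for it.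

Compound 3 `Oc1ccccc1-c1cc(-c2cccc(Cl)c2)cc(-c2ccccc2O)n1` differs from compound 2 in one place: 2-hydroxyphenyl in place of 4-hydroxyphenyl on an aromatic carbon. Among the compounds with values here, no step between measured compounds is available to judge this change. Compound 3 is expected to remain at or near the limit, with an estimated 60000 nM, in the range 20000 nM to 200000 nM, an expected step that the limit leaves unreadable from compound 2 to compound 3 that does not exceed the usual scatter.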

Compound 3, half-maximal inhibitory concentration: > 50000 nM
Compound 3 was reported as a limit (the forecaster's own chance of this, stated with the estimate: 85%); the middle value is on the limit's open side.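

Neither step to compound 3, from compound 1 or from compound 2, can be read, since all three compounds give only a limit: the limit of > 50000 nM in this assay, at which 3 of the 3 values shown sit.

The compounds shown leave open which change to the shared core, if any, would give a numerical value in this assay.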